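Adding a Methoxy Group to an Arylpiperazine Antagonist

This account rests on a few compounds, and the source may have more. Where it says the series, first, only, none or still open, it means among the compounds named here.

Of the compounds shown here, three sharing one core have been measured in a functional assay for antagonist activity at Alpha-1A adrenergic receptor (Oryctolagus cuniculus); a higher number here means weaker binding, a lower number tighter binding. Compound 1 `CN(C)C(=O)c1cccnc1NCCCN1CCN(c2ccccc2OC(F)(F)F)CC1` gives 3.16 nM. Compound 2 `CN(C)C(=O)c1cccnc1NCCCN1CCN(c2ccccc2-c2ccccc2)CC1` gives 1.26 nM, and compound 3 `Cc1ccccc1N1CCN(CCCNc2ncccc2C(=O)N(C)C)CC1` gives 2 nM. Within this small set compound 3 stands second of the three numbers; one of its steps is a 1.6-fold lower number from compound 1 to compound 3 (0.20 log units; within the scatter) and the other is a 1.6-fold higher number from compound 2 to compound 3 (0.20 log units; within the scatter), so no ordering among the three can be claimed. Going by the values given here, the only step beyond the scatter is a 2.5-fold lower number from compound 1 to compound 2 (0.40 log units; beyond the scatter).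

Compound 4 `COc1cc(C)ccc1N1CCN(CCCNc2ncccc2C(=O)N(C)C)CC1` differs from compound 3 in one place: 2-methoxy-4-methylphenyl in place of 2-methylphenyl on an amine nitrogen in a ring. Among the compounds with values here, the earlier steps that bear on this are the swaps on the same aromatic ring, trifluoromethoxy to methyl and phenyl to methyl, both of which stayed within the scatter, and the one step beyond it, trifluoromethoxy to phenyl, which was only modest. Three substituents of quite different kinds on this ring therefore gave numbers within a narrow band. On that basis the step of a 1.1-fold higher number from compound 3 to compound 4 (0.04 log units; within the scatter) is expected to be small, likely within the scatter, with no direction preferred. Compound 4 is estimated at 2.2 nM, with a range from 0.9 nM to 5.5 nM.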

Compound 4, dissociation constant: 0.794 nM
The estimate for compound 4 lay 2.8-fold (0.44 log units) above the measured number; the whole stated range lies above it.
By their numbers in this assay, from the lowest: compounds 4, 2, 3 and 1 (each within the scatter of the next, the first and the last beyond it).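

In this assay, replacing 2-methylphenyl with 2-methoxy-4-methylphenyl on the ring amine nitrogen gives a 2.5-fold lower number from compound 3 to compound 4 (0.40 log units; beyond the scatter), a modest change but one that clears the usual scatter. Going by these compounds alone, the only earlier step beyond the scatter on this aromatic ring was a 2.5-fold lower number from compound 1 to compound 2 (0.40 log units; beyond the scatter), a swap of one substituent for another, whereas the new group is the first here to carry a methoxy and the first with two substituents on the ring, and it shows that such a group is tolerated and can shift the number further than the scatter allows. Nothing measured here explains this shift.

The entering group differs from the leaving one in two ways at once, gaining a methoxy and carrying its methyl at a different numbered place, so this single step cannot assign the change to either, and 2-methoxyphenyl and 4-methylphenyl on the same nitrogen would separate the two. On these data alone, it also remains open whether a larger ether, as in 2-ethoxyphenyl, or a chlorine in place of the methyl, as in 4-chloro-2-methoxyphenyl, would keep, extend or lose the step.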